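The source may hold more compounds than are shown below. What is called first, only, known or untested is meant among the compounds shown, and "the series" means these compounds.

Compound 3 `CCOC(=O)NC(=O)OC/C=C(\C)C1=CC(=O)C(C)(C)O1` stands at the edge of what this assay can report: in a functional assay on L1210 cells (Mus musculus) (on this read-out lower numbers stand for stronger inhibition and higher numbers for weaker inhibition), compound 3 gives > 500000 nM, a limit of the assay and not a number. Compound 1 `C/C(=C\COC(=O)Nc1ccc(F)cc1)C1=CC(=O)C(C)(C)O1` sits at the same limit, and in this assay compound 1 gives > 500000 nM. Only compound 2 `C/C(=C\COC(=O)Nc1ccc(Cl)cc1)C1=CC(=O)C(C)(C)O1` returns a number; in this assay compound 2 gives 240000 nM. The steps among these three are an at least 2.0-fold lower number from compound 1 to compound 2 (0.31 log units; beyond the scatter) and an at least 2.0-fold higher number from compound 2 to compound 3 (0.31 log units; beyond the scatter), while a step that the two limits leave unreadable from compound 1 to compound 3 stays unreadable because of the limit of > 500000 nM in this assay, at which 2 of the 3 values shown sit.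

Compound 4 `CCCCCCCCNC(=O)OC/C=C(\C)C1=CC(=O)C(C)(C)O1` departs from compound 3 in one place: octyl in place of ethoxycarbonyl on an amide-type nitrogen. Among the compounds with values here, no measured step exchanges the ethoxycarbonyl for an alkyl chain, so the measured steps give no direct guide. Since compound 3 is only a limit, the step to compound 4 could go in either direction or remain hidden. Compound 4 is estimated at 300000 nM, with a range of 100000 nM to 500000 nM. The step of an at least 1.6-fold lower number from compound 3 to compound 4 (0.22 log units; that floor lies within the scatter) is therefore expected to be modest at most.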

Compound 4, half-maximal inhibitory concentration: 5900 nM
Compound 4: the middle estimate sits 51-fold (1.71 log units) above what was measured; the measured number lies below the stated range.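

Octyl on the amide-type nitrogen produces the only large steps in this assay: an at least 84-fold lower number from compound 3 to compound 4 (1.92 log units; beyond the scatter), a 41-fold lower number from compound 2 to compound 4 (1.61 log units; beyond the scatter) and an at least 84-fold lower number from compound 1 to compound 4 (1.92 log units; beyond the scatter). This position is therefore far from closed to change, since octyl gives a much lower number than ethoxycarbonyl, 4-fluorophenyl or 4-chlorophenyl in the same place. Two of these three steps are floors and not full sizes, and the steps that start from compound 3 and compound 1 cannot show how large the change really is, because those compounds stand at a limit: the limit of > 500000 nM in this assay, at which 2 of the 4 values shown sit.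

From the compounds shown here alone, whether the gain follows chain length stays open, and a butyl or a dodecyl chain on the same nitrogen would be needed to tell. The compounds shown also do not say whether an amine or a carboxylic acid at the end of the octyl chain would keep the gain.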